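A Fluorine on the Phenyl Ring of Compound 2

The source may hold more compounds than are shown below. What is called first, only, known or untested is meant among the compounds shown, and "the series" means these compounds.

Three related compounds were tested in a functional assay on the whole organism (strain Swiss) with Mus musculus as the target, in the maximal electroshock model, with a stated time of 2 h, at a dose of 300 mg/kg by the intraperitoneal route; on this read-out higher numbers stand for a stronger effect at the one dose given and lower numbers for a weaker effect. Compound 1 `COCC(C(=O)N1CCN(c2cccc(C(F)(F)F)c2)CC1)N1C(=O)CCC1=O` gives 100% in this assay. Compound 2 `CC(C(=O)N1CCN(c2ccccc2)CC1)N1C(=O)CCC1=O` gives 0%, and compound 3 `CCC(C(=O)N1CCN(c2cccc(OC)c2)CC1)N1C(=O)CCC1=O` gives 0%; compound 2 is level with compound 3 at the digits shown, both the lowest of the three, and stands far below compound 1. Compound 4 `CC(C(=O)N1CCN(c2ccccc2F)CC1)N1C(=O)CCC1=O` has not yet been measured. It differs from compound 2 in one place: fluoro in place of hydrogen on an aromatic carbon. Among the compounds with values here, no measured pair differs by exactly this change, so the step from compound 2 to compound 4 cannot be read from the numbers. A small rise at most is expected, a number 15 percentage points higher from compound 2 to compound 4 (beyond the scatter), which may well stay within the scatter. Compound 4 is therefore estimated at 15%, within a range from 0% to 50%.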

Compound 4, a percentage reported as activity, at one dose (the size of the read-out at that dose, not a potency): 25%
Estimate against measurement, compound 4: 10 percentage points below; the range from low to high includes it.
By their numbers in this assay, from the lowest: compounds 2 and 3 (each within the scatter of the next); then compound 4; then compound 1.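

In this assay, within the data shown here, the change from phenyl to 2-fluorophenyl gives a number 25 percentage points higher from compound 2 to compound 4 (beyond the scatter) and is the first single change in this set whose size can be read directly. It shows that this aromatic carbon, ortho to a large group, can take fluoro with a measurable gain, though the result stays far short of compound 1. No measurement at hand explains the rise.

As far as these compounds go, what chloro, methyl or an amine would do at this same place remains open. The other steps cannot be read, as compound 1 and compound 3 each differ from compound 4 in more than one place.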